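Swapping the aryl group on the urea: compound 4

The source may hold more compounds than are shown below. What is called first, only, known or untested is meant among the compounds shown, and "the series" means these compounds.

Compound 1 `Cc1ccccc1NC(=O)Nc1cc(C(C)(C)C)nn1-c1ccccc1` gives 8.6 degrees C in an assay on isolated protein for inhibition of serine/threonine-protein kinase 10 (Homo sapiens), read by thermal shift assay, tested at 10 uM; a higher number here means that the compound stabilises the target more against heat, a lower number that the compound stabilises the target less.
Compound 2 `CCOc1ccc(NC(=O)Nc2cc(C(C)(C)C)nn2-c2ccccc2)cc1` gives 0.8 degrees C in this assay.
Compound 3 `CC(C)(C)c1cc(NC(=O)Nc2cc(C(F)(F)F)cc(C(F)(F)F)c2)n(-c2ccccc2)n1` gives -0.5 degrees C in this assay.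

Compound 2 stands second highest of the three in this assay, with compound 3 a little lower and compound 1 well above it. The step to compound 4 `Cc1cc(C)cc(NC(=O)Nc2cc(C(C)(C)C)nn2-c2ccccc2)c1` makes this change: 3,5-dimethylphenyl in place of 4-ethoxyphenyl on an amide-type nitrogen. For the measured compounds named here, only one measured step bears on this place: a number 7.8 degrees C lower from compound 1 to compound 2 (beyond the scatter), a large loss when the methyl-bearing ring gave way to the ethoxy-bearing one. Bringing two methyl groups back onto the ring is expected to recover part of that loss, though how much is uncertain, since no measured compound carries the 3,5-dimethylphenyl group. The expected step is a number 2.7 degrees C higher from compound 2 to compound 4 (beyond the scatter). Compound 4 is therefore estimated at 3.5 degrees C, between 0 degrees C and 8 degrees C.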

Compound 4, shift of the target's melting temperature: -0.3 degrees C
Compound 4: middle estimate off by 3.8 degrees C, on the high side; measured number outside the range, below it.
By their numbers in this assay, from the lowest: compounds 3 and 4 (each within the scatter of the next); then compound 2; then compound 1.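

Carrying methyl groups on the ring does not by itself bring back the high number of compound 1: 3,5-dimethylphenyl gives a number 8.9 degrees C lower from compound 1 to compound 4 (beyond the scatter) on the amide-type nitrogen. Losing 4-ethoxyphenyl brings no recovery either, since the change gives a number 1.1 degrees C lower from compound 2 to compound 4 (beyond the scatter) in this assay rather than a gain. No measurement shown here explains why these aryl groups differ.

Still open, as far as these compounds go, is whether 2-methylphenyl is unusual in this set for its methyl group or for that group's place on the ring. The compounds shown leave open how 2-chlorophenyl, 2-ethylphenyl or 3-methylphenyl would compare.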